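Amide aryl exchange in a prostanoid receptor antagonist series

This account rests on a few compounds, and the source may have more. Where it says the series, first, only, none or still open, it means among the compounds named here.

Measured compounds:
compound 1 `CN1C[C@@H](COc2ccc(C(=O)N(C)c3cccc(CC(=O)O)c3)cc2)Oc2ccccc21`: "not determined" (no result reported)
compound 2 `CN1C[C@@H](COc2ccc(C(=O)Nc3cccc(CC(=O)O)c3)c(Cl)c2)Oc2ccccc21`: 20 nM
compound 3 `Cc1cc(OC[C@@H]2CN(C)c3ccccc3O2)ccc1C(=O)Nc1cc(CC(=O)O)ccc1Cl`: "not determined" (no result reported)

In a functional assay on CHO cells for antagonist activity at prostaglandin D2 receptor (Mus musculus), read by cAMP accumulation (on this read-out lower numbers stand for stronger inhibition and higher numbers for weaker inhibition), compound 2 gives 20 nM. For compound 1 no result is available, and compound 3 likewise has no number in this assay, so compound 3 cannot be placed on the measured scale; the only anchor in the set is compound 2. Compound 4 `Cc1cc(OC[C@@H]2CN(C)c3ccccc3O2)ccc1C(=O)Nc1ccc(F)c(CC(=O)O)c1` carries 3-(carboxymethyl)-4-fluorophenyl in place of 5-(carboxymethyl)-2-chlorophenyl on an amide-type nitrogen. Among the compounds with values here, no step between measured compounds exists, and compound 2 and compound 4 differ in more than one place, which leaves no direction to be read from the data. The expectation for compound 4 in this assay is a potency in the region already seen, with a wide band. Compound 4 is estimated at 30 nM, range 5 nM to 200 nM.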

Compound 4, half-maximal inhibitory concentration: 1.2 nM
Compound 4: the middle estimate sits 25-fold (1.40 log units) above what was measured; the measured number lies below the stated range.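

In this assay compound 4 gives 1.2 nM, but no new step can be read: compound 3 has no number there, and compound 2 differs from compound 4 in more than one place. The compounds shown leave open what exchanging 5-(carboxymethyl)-2-chlorophenyl for 3-(carboxymethyl)-4-fluorophenyl does to potency on its own. No supporting data bear on this result.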